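Sulfonyl aryl exchange: from compound 2 to compound 4

A few compounds are considered here, and "the series" means these few. Any claim that something is new, unique, unknown or untested is made for them only; others in the source may bear on it.

Measured so far:
compound 1 `O=S(=O)(Nc1ccc(-c2nc3ccccc3o2)cc1)c1cccs1`: 63000 nM
compound 2 `COc1ccc(S(=O)(=O)Nc2ccc(-c3nc4ccccc4o3)cc2)cc1`: > 100000 nM
compound 3 `O=S(=O)(Nc1ccc2oc(-c3ccc(NS(=O)(=O)c4cccc5nonc45)cc3)nc2c1)c1ccc(Cl)s1`: 13000 nM

In an assay on cells for inhibition of HSP60/HSP10 (Homo sapiens), with a stated time of 60 min (on this read-out lower numbers stand for stronger inhibition and higher numbers for weaker inhibition), compound 1 gives 63000 nM. Compound 2 reaches only > 100000 nM, which is a limit of the assay and not a number. Compound 3 gives 13000 nM. The one-place step an at least 1.5-fold higher number from compound 1 to compound 2 (0.20 log units; that floor lies within the scatter) rests on that limit (the limit of > 100000 nM in this assay, at which 1 of the 3 values shown sits). Compound 4 `O=S(=O)(Nc1ccc(-c2nc3ccccc3o2)cc1)c1cccc(Cl)c1` is not yet measured; it differs from compound 2 as 3-chlorophenyl in place of 4-methoxyphenyl on a sulfonyl sulfur. Among the compounds with values here, no measured single step covers a chlorine on this aryl, so the expectation leans on compound 1 and compound 3, which hold other sulfonyl aryls and sit at numbers rather than the limit. The expected step is an at least 1.6-fold lower number from compound 2 to compound 4 (0.22 log units; that floor lies within the scatter), back toward a measurable number. Compound 4 is estimated at 60000 nM (range 20000 nM to 150000 nM).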

Compound 4, half-maximal inhibitory concentration: 54000 nM
Compound 4: middle estimate off by 1.1-fold (0.05 log units), on the high side; the measured number falls inside the stated range.
By their numbers in this assay, from the lowest: compound 3; then compounds 4 and 1 (each within the scatter of the next). At a limit, above all of these: compound 2.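

Compound 2 holds a limit and not a number, so this change can be sized only as a floor: the limit of > 100000 nM in this assay, at which 1 of the 4 values shown sits. In this assay, 3-chlorophenyl on the sulfonyl sulfur returns the series to a measurable number, with an at least 1.8-fold lower number from compound 2 to compound 4 (0.26 log units; that floor lies within the scatter). Thiophen-2-yl and 3-chlorophenyl are not told apart at this position: a 1.2-fold lower number from compound 1 to compound 4 (0.07 log units; within the scatter).

Still open, on these data alone, is which part of the change separates compound 2 from compound 4, the loss of the methoxy group or the gain of chlorine. Also open, as far as these compounds go, is how an amine or a carboxylic acid on the sulfonyl aryl would read.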